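Chloro added to the thiophene ring of compound 1

A few compounds are considered here, and "the series" means these few. Any claim that something is new, unique, unknown or untested is made for them only; others in the source may bear on it.

Going by the values given here, compound 1 `CSc1cccc(Nc2nc(-c3cccs3)cs2)c1` is the only member of the series with a reported number: in an assay on CFBE41o cells with Cystic fibrosis transmembrane conductance regulator variant F508del (Homo sapiens) as the target, with a stated time of 24 h (on this read-out lower numbers stand for an effect already at smaller amounts and higher numbers for an effect only at larger amounts of compound), compound 1 gives 8500 nM. Compound 2 `CCOC(=O)c1cc(-c2csc(Nc3cccc(SC)c3)n2)on1` is recorded in this assay as "not active" (no number reported), without a figure. Compound 3 `CSc1cccc(Nc2nc(-c3cc(Cl)cs3)cs2)c1` differs from compound 1 by chloro in place of hydrogen on an aromatic carbon. Among the compounds with values here, no measured pair shows such a change here, so the size of the step in this assay is an expectation only; a shift no larger than the usual scatter, leaning toward lower concentrations, is expected, giving a 1.4-fold lower number from compound 1 to compound 3 (0.15 log units; within the scatter). Compound 3 is thus estimated at 6000 nM, between 2000 nM and 20000 nM.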

Compound 3, half-maximal effective concentration: "not active" (no number reported)
The entry for compound 3 holds no number, and the estimate cannot be compared.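

Going by these compounds alone, compound 3, like compound 2, carries no number in this assay, so no step from compound 1 to compound 3 can be read, and no supporting measurement bears on this result. The compounds shown leave open which changes to compound 1 keep a measurable effect.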